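This account rests on a few compounds, and the source may have more. Where it says the series, first, only, none or still open, it means among the compounds named here.

Within the data shown here, compound 2 `Nc1ccc(Nc2c(C(=O)NCc3ccc(F)cc3)nc(Br)c3cccnc23)cc1` is the only compound that returns a number in a functional assay on HCT-116 cells (Homo sapiens) for cytotoxicity, read by MTT assay, with a stated time of 72 h (a higher number here means a weaker inhibitor, a lower number a stronger inhibitor), where compound 2 gives 10000 nM. Compound 1 `N[C@H]1CC[C@H](Nc2c(C(=O)NCc3ccc(F)cc3)nc(N3CCCCS3(=O)=O)c3cccnc23)CC1` reaches only the limit of > 10000 nM in this assay, a limit rather than a number. Compound 3 `O=C(NCc1ccc(F)cc1)c1nc(Br)c2cccnc2c1N1CCNCC1` differs from compound 2 by piperazin-1-yl in place of (4-aminophenyl)amino on an aromatic carbon. Among the measured compounds shown here, with two weak compounds as the only guide, the expected step is no change at the digits printed from compound 2 to compound 3 (within the scatter), no more than the scatter. Compound 3 is therefore estimated at 10000 nM in this assay, within a range of 3000 nM to 30000 nM.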

Compound 3, half-maximal inhibitory concentration: > 10000 nM
Compound 3 gave a limit, no number; the forecaster's own chance of this, stated with the estimate: 45%; the middle value sits exactly at the limit.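

In this assay, piperazin-1-yl in place of (4-aminophenyl)amino on this aromatic carbon, para to a bromo group, gives a number no lower from compound 2 to compound 3 (the limit leaves the size open), so this change brings no gain in potency, and the size of the step cannot be read. For compound 3 the result is a limit, > 10000 nM. The compounds shown now crowd the edge of the assay's range: the limit of > 10000 nM in this assay, at which 2 of the 3 values shown sit.

Going by these compounds, whether a morpholin-4-yl group or an open-chain amine on this carbon would give a stronger number stays open. So does the effect of replacing the bromo group in compound 3 with another group.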